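The compounds below may be only part of what the source reports. "The series", "measured", "known", "first", "only" and "open" are said of these compounds alone.

Measured in a functional assay on MCF7 cells (Homo sapiens) for cytotoxicity, read by neutral red uptake, with a stated time of 3 days; a higher number here means a weaker inhibitor, a lower number a stronger inhibitor:
Compound 1 `C[S+]([O-])c1c(F)c(N)c2c(=O)cc(-c3ccc(N)c(F)c3)oc2c1F`: 2500 nM
Compound 2 `Nc1ccc(-c2cc(=O)c3c(N)c(F)c(O)c(F)c3o2)cc1F`: a limit of the assay, > 10000 nM
Compound 3 `CCC(=O)OCc1c(F)c(N)c2c(=O)cc(-c3ccc(N)c(F)c3)oc2c1F`: 130 nM

Compound 3 stands lowest of the two numbers shown; the nearest is compound 1, and the step of a 19-fold lower number from compound 1 to compound 3 (1.28 log units; beyond the scatter) is large. The step of an at least 76-fold lower number from compound 2 to compound 3 (1.88 log units; beyond the scatter) is also large, though compound 2 gives only a limit of the assay.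

Compound 4 `CCCCCC(=O)OCc1c(F)c(N)c2c(=O)cc(-c3ccc(N)c(F)c3)oc2c1F` differs from compound 3 by propyl in place of hydrogen on a saturated chain carbon, two bonds along the chain from a carbonyl carbon. Among the measured compounds shown here, both measured steps replaced the whole group on the aromatic carbon of the shared core; neither lengthened the ester chain, so no measured step bears directly on this change. The expectation is therefore no step beyond the scatter, no change at the digits printed from compound 3 to compound 4 (within the scatter). Compound 4 is estimated at 130 nM, in the range 40 nM to 400 nM.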

Compound 4, half-maximal inhibitory concentration: 160 nM
The estimate for compound 4 lay 1.2-fold (0.09 log units) below the measured number; the measured number falls inside the stated range.
By their numbers in this assay, from the lowest: compounds 3 and 4 (each within the scatter of the next); then compound 1. At a limit, above all of these: compound 2.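

In this assay the longer ester chain of compound 4 leaves the number where it was (a 1.2-fold higher number from compound 3 to compound 4 (0.09 log units; within the scatter)). The large distance from the other groups on the aromatic carbon therefore holds with propyl added on the saturated chain carbon (a 16-fold lower number from compound 1 to compound 4 (1.19 log units; beyond the scatter)) (an at least 62-fold lower number from compound 2 to compound 4 (1.79 log units; beyond the scatter)). The second of these steps rests on compound 2, which gives only a limit of the assay: the limit of > 10000 nM in this assay, at which 1 of the 4 values shown sits.

A much longer chain, a branched chain or an amine at the chain's end could still behave differently. These compounds also leave open whether an amide in place of the ester would keep the number this low.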